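A few compounds are considered here, and "the series" means these few. Any claim that something is new, unique, unknown or untested is made for them only; others in the source may bear on it.

Measured in an ADME assay on the whole organism (Mus musculus, strain CD1) for pharmacokinetics, at a dose of 2 mg/kg by the intravenous route; on this read-out higher numbers stand for wider distribution into tissues and lower numbers for narrower distribution:
- compound 1 `CN1CCC(Oc2ccc(N3C(=S)N(c4cnc(C#N)c(C(F)(F)F)c4)C(=O)C34CCC4)cn2)CC1`: 7.69 L/kg
- compound 2 `Cc1cc(N2C(=O)C3(CCC3)N(c3ccc(OC4CCNCC4)nc3)C2=S)cnc1C#N`: 4.35 L/kg
- compound 3 `N#Cc1ncc(N2C(=O)C3(CCC3)N(c3ccc(CN4CCNCC4)cc3)C2=S)cc1C(F)(F)F`: 16.8 L/kg

Compound 2 lies within the scatter of compound 1, while compound 3 reads higher than compound 2, beyond the scatter. Compound 4 `N#Cc1ncc(N2C(=O)C3(CCC3)N(c3ccc(OC4CCNCC4)nc3)C2=S)cc1C(F)(F)F` is not yet measured. Relative to compound 2 it has trifluoromethyl in place of methyl on an aromatic carbon. Going by the values given here, no measured pair isolates this change. Compound 1 also carries trifluoromethyl and gives 7.69 L/kg, so only a small upward change in this assay is expected, probably within the scatter. The expected step is a 1.5-fold higher number from compound 2 to compound 4 (0.17 log units; within the scatter). For compound 4 the estimate is 6.5 L/kg, with an expected range of 3.5 L/kg to 12 L/kg.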

Compound 4, volume of distribution at steady state: 6.11 L/kg
For compound 4 the middle estimate is 1.1-fold (0.03 log units) above the measured one; low and high end bracket the measured number.
By their numbers in this assay, from the lowest: compounds 2, 4 and 1 (each within the scatter of the next); then compound 3.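

In this assay, trifluoromethyl in place of methyl on an aromatic carbon, ortho to a cyano group, gives a 1.4-fold higher number from compound 2 to compound 4 (0.15 log units; within the scatter) and so stays within the scatter at this position. Hydrogen in place of methyl on an amine nitrogen in a ring gives a 1.3-fold lower number from compound 1 to compound 4 (0.10 log units; within the scatter) and also stays within the scatter. No measurement available here explains why either change is this small. Open, going by these compounds, is whether chlorine or a carboxylic acid at this aromatic carbon would give a step beyond the scatter. Also open, on these data alone, is whether an ethyl group or a longer chain on the ring amine nitrogen would do so.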